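Ethyl to cyclopropyl on the aromatic nitrogen

The source may hold more compounds than are shown below. What is called first, only, known or untested is meant among the compounds shown, and "the series" means these compounds.

- Compound 1 `Cc1c(C(=O)NCCCN2CCN(C)CC2)c(-c2ccccc2)c(-c2ccc(Cl)cc2)n1C` gives > 10000 nM as a limit of the assay
- Compound 2 `CNC(=O)c1c(-c2cccc(N3CCN(c4ccc(NS(=O)(=O)c5ccc(N[C@H](CCN(C)C)CSc6ccccc6)c([N+](=O)[O-])c5)cc4)CC3)c2)c(-c2ccc(Cl)cc2)n(C)c1C` gives 109 nM
- Compound 3 `CCn1c(C)c(C(=O)O)c(-c2cccc(N3CCN(c4ccc(NS(=O)(=O)c5ccc(N[C@H](CCN(C)C)CSc6ccccc6)c([N+](=O)[O-])c5)cc4)CC3)c2)c1-c1ccc(Cl)cc1` gives 17.7 nM

For the measured compounds named here, in a functional assay on NCI-H1417 cells (Homo sapiens) for antiproliferative activity, read by WST assay, with a stated time of 4 days (a higher number here means a weaker inhibitor, a lower number a stronger inhibitor), compound 3 holds the lowest number so far (17.7 nM) and stands clear of compound 2 (109 nM) by more than the usual scatter. Compound 4 `Cc1c(C(=O)O)c(-c2cccc(N3CCN(c4ccc(NS(=O)(=O)c5ccc(N[C@H](CCN(C)C)CSc6ccccc6)c([N+](=O)[O-])c5)cc4)CC3)c2)c(-c2ccc(Cl)cc2)n1C1CC1` keeps the rest of compound 3 and carries cyclopropyl in place of ethyl on an aromatic nitrogen next to the ring atom that bears a 4-chlorophenyl group. Going by the values given here, no measured pair isolates a change at this place, so the expectation rests on the structural change alone. The carboxy group and the large group stay as they are in compound 3, and no shift beyond the scatter is expected in this assay from this swap. The estimated change a 1.1-fold higher number from compound 3 to compound 4 (0.05 log units; within the scatter) is accordingly small. Compound 4 is expected at about 20 nM with an estimated range of 7 nM to 55 nM in this measurement.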

Compound 4, half-maximal inhibitory concentration: 154 nM
Compound 4: middle estimate off by 7.7-fold (0.89 log units), on the low side; measured number outside the range, above it.
By their numbers in this assay, from the lowest: compound 3; then compounds 2 and 4 (each within the scatter of the next). At a limit, above all of these: compound 1.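

Working from the one-place step at this position, in this assay cyclopropyl in place of ethyl on the aromatic nitrogen gives an 8.7-fold higher number from compound 3 to compound 4 (0.94 log units; beyond the scatter). The swap leaves the counts of hydrogen-bond donors and acceptors and the net charge unchanged, and the carboxy group and the large group stay fixed, so this nitrogen substituent alone is enough to move the number beyond the scatter. No measurement shown here accounts for the size of this step.

On these data alone, whether an isopropyl group or a longer chain such as propyl on this nitrogen would stay close to compound 3 or follow compound 4 remains open. Also open, as far as these compounds go, is whether the same step would appear with a tetrazole in place of the carboxy group.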